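This account rests on a few compounds, and the source may have more. Where it says the series, first, only, none or still open, it means among the compounds named here.

Measured so far:
Compound 1 `COc1ccc(OC)c(C2=C(c3cc(OC)c(OC)c(OC)c3)C(=O)CC2O[SiH2]C(C)(C)C)c1`: 6.5 ug/mL
Compound 2 `COc1ccc(C2=C(c3cc(OC)c(OC)c(OC)c3)C(=O)C(O)C2)cc1NC(=O)c1ccccc1`: > 100 ug/mL
Compound 3 `COc1ccc(C2=C(c3cc(OC)c(OC)c(OC)c3)C(=O)C(OC(C)=O)C2)cc1OC(C)C`: > 100 ug/mL

All three were tested in an ADME assay on ECV-304 cells (Homo sapiens) for cytotoxicity, read by MTT assay, with a stated time of 72 h; on this read-out lower numbers stand for stronger inhibition and higher numbers for weaker inhibition. Compound 1 gives a number, 6.5 ug/mL. Compound 2 gives only a limit, > 100 ug/mL, which is the ceiling of this assay and not a measured number. Compound 3 likewise gives only a limit, > 100 ug/mL. Compound 2 therefore sits at the limit of > 100 ug/mL in this assay, at which 2 of the 3 values shown sit, and nothing more precise is known about it.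

Compound 4 `COc1ccc(C2=C(c3cc(OC)c(OC)c(OC)c3)C(=O)C(O)C2)cc1F` differs from compound 2 by a single change: fluoro in place of benzamido on an aromatic carbon. For the measured compounds named here, no pair of measured compounds differs in just one place, so no measured step shows how large such a change can be. Compound 1 shows that a number inside the range is reachable, but it differs from compound 2 in several places at once.

For compound 4 the expected step is an at least 2.0-fold lower number from compound 2 to compound 4 (0.30 log units; that floor lies within the scatter), toward stronger inhibition, with wide uncertainty. Compound 4 is expected to give about 50 ug/mL, in a range from 10 ug/mL to 100 ug/mL.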

Compound 4, half-maximal inhibitory concentration: 19.5 ug/mL
Compound 4: the middle estimate sits 2.6-fold (0.41 log units) above what was measured; low and high end bracket the measured number.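

In this assay the change at this aromatic carbon, ortho to a methoxy group, is the only step shown between compounds that differ in one place. Putting fluoro in place of benzamido gives an at least 5.1-fold lower number from compound 2 to compound 4 (0.70 log units; beyond the scatter) and so shows that the shared core does not need the benzamido group to give a real number here, since a single fluoro at this place is enough. The full size of this step stays unknown because compound 2 carries only a limit: the limit of > 100 ug/mL in this assay, at which 2 of the 4 values shown sit.

As far as these compounds go, only benzamido and fluoro can be compared at this place, so it remains open how an amine, a chloro group or a plain hydrogen would read there. Compound 1 and compound 3 each differ from compound 4 in more than one place, so they cannot show whether this change behaves the same way on other versions of the core.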